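A few compounds are considered here, and "the series" means these few. Any claim that something is new, unique, unknown or untested is made for them only; others in the source may bear on it.

Compound 1, `COc1cccc(/C=C/C(=O)c2ccc(OC)c3c2OC(C)(C)C=C3)c1`: in a functional assay on SK-OV-3 cells (Homo sapiens) for antiproliferative activity, read by MTT assay, with a stated time of 24 h (on this read-out higher numbers stand for weaker inhibition and lower numbers for stronger inhibition), compound 1 gives 9360 nM.
Compound 2, `COc1ccc(/C=C/C(=O)c2ccc(OC)c3c2OC(C)(C)C=C3)c(F)c1`: compound 2 gives 4880 nM.
Compound 3, `COc1ccc(C(=O)/C=C/c2ccc(-c3ccccc3)cc2)c2c1C=CC(C)(C)O2`: compound 3 gives > 10000 nM, which is a limit of the assay and not a number.

Compound 3 therefore sits at the edge of the numbers shown (the limit of > 10000 nM in this assay, at which 1 of the 3 values shown sits), and all that can be said of it is that it lies beyond them. Compound 4, `COc1ccc(C(=O)/C=C/c2ccc([N+](=O)[O-])cc2)c2c1C=CC(C)(C)O2`, differs from compound 3 by nitro in place of phenyl on an aromatic carbon. Going by the values given here, the only measured step, a 1.9-fold lower number from compound 1 to compound 2 (0.28 log units; within the scatter), changes the other aryl ring and lies within the scatter; no measured step touches the group exchanged here. Among the compounds with values here, with compound 3 known only as a limit, no size of step can be drawn from the data, and the expected step of an at least 1.1-fold lower number from compound 3 to compound 4 (0.04 log units; that floor lies within the scatter) is set near zero. Compound 4 is therefore expected to give about 9000 nM, with a range from 2500 nM to 30000 nM.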

Compound 4, half-maximal inhibitory concentration: 3420 nM
Compound 4: middle estimate off by 2.6-fold (0.42 log units), on the high side, and the stated range covers the measured number.
By their numbers in this assay, from the lowest: compounds 4, 2 and 1 (each within the scatter of the next, the first and the last beyond it). At a limit, above all of these: compound 3.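

Nitro in place of phenyl on an aromatic carbon, para to a large group, gives an at least 2.9-fold lower number from compound 3 to compound 4 (0.46 log units; beyond the scatter); this is the first step at this position, and its size is only a floor, as compound 3 stands at a limit of the assay: the limit of > 10000 nM in this assay, at which 1 of the 4 values shown sits.

In this assay, 4-nitrophenyl gives a 1.4-fold lower number from compound 2 to compound 4 (0.15 log units; within the scatter), and a 2.7-fold lower number from compound 1 to compound 4 (0.44 log units; beyond the scatter). So a measured number returns with nitro in this place, level within the scatter with compound 2.

Going by these compounds, how an amine or a carboxylic acid in the same place would compare with nitro stays open.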